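A Fluoro Ortho to Bromo: What to Expect for Compound 4

The source may hold more compounds than are shown below. What is called first, only, known or untested is meant among the compounds shown, and "the series" means these compounds.

Of the compounds shown here, three sharing one core have been measured in an assay on HeLa cells for inhibition of Indoleamine 2,3-dioxygenase 1 (Homo sapiens), read by spectrophotometry, with a stated time of 24 h; on this read-out higher numbers stand for an effect only at larger amounts of compound and lower numbers for an effect already at smaller amounts. Compound 1 `CC(=O)Nc1ccc(S(=O)(=O)NNc2ccc(C#N)cc2)cc1` gives 1390 nM, compound 2 `CC(=O)Nc1ccc(S(=O)(=O)NNc2ccc(Cl)cc2)cc1` gives 142 nM, and compound 3 `CC(=O)Nc1ccc(S(=O)(=O)NNc2ccc(Br)cc2)cc1` gives 85 nM, the lowest number of the three, although its step to compound 2 lies within the scatter. The steps of a 9.8-fold lower number from compound 1 to compound 2 (0.99 log units; beyond the scatter) and a 16-fold lower number from compound 1 to compound 3 (1.21 log units; beyond the scatter) were beyond the scatter, whereas a 1.7-fold lower number from compound 2 to compound 3 (0.22 log units; within the scatter) was not. Compound 4 `CC(=O)Nc1ccc(S(=O)(=O)NNc2ccc(Br)c(F)c2)cc1` differs from compound 3 by fluoro in place of hydrogen on an aromatic carbon. Among the compounds with values here, none of the measured steps adds a second group; each exchanges one group for another, so no step bears directly on this change. The step is therefore expected to stay within the scatter, no change at the digits printed from compound 3 to compound 4 (within the scatter). Compound 4 is estimated at 85 nM, within a range from 40 nM to 200 nM.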

Compound 4, half-maximal effective concentration: 187 nM
Compound 4: the middle estimate sits 2.2-fold (0.34 log units) below what was measured; the range from low to high includes it.
By their numbers in this assay, from the lowest: compounds 3, 2 and 4 (each within the scatter of the next, the first and the last beyond it); then compound 1.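

Adding fluoro ortho to a bromo group gives a 2.2-fold higher number from compound 3 to compound 4 (0.34 log units; beyond the scatter) and so shows that this carbon of the ring is not indifferent to substitution. Unlike the earlier steps, which exchange one group for another, this one adds a group, and a single fluorine atom is enough to move the number beyond the scatter. No measurement available here accounts for the shift.

From the compounds shown here alone, whether the rise belongs to fluoro itself or to any group on this carbon stays open. A methyl group or an amine in the same place would help to separate the two.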